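This account rests on a few compounds, and the source may have more. Where it says the series, first, only, none or still open, it means among the compounds named here.

Of the compounds shown here, three sharing one core have been tested in a functional assay on PC-3 cells (Homo sapiens) for cytotoxicity, read by MTT assay, with a stated time of 72 h; a lower number here means a stronger inhibitor, a higher number a weaker inhibitor. Compound 1 `COc1ccc(Cn2nc(-c3ccccc3)c3cc(C(=N)Nc4ccccc4)ncc32)cc1` gives 6300 nM in this assay. Compound 2 `COc1ccc(Cn2nc(-c3ccccc3)c3cc(C(=N)Nc4ccc(N5CCN(C)CC5)cc4)nc(NC4CCCCC4)c32)cc1` gives 3540 nM. Compound 3 `CN1CCN(c2ccc(NC(=N)c3cc4c(-c5ccccc5)n[nH]c4cn3)cc2)CC1` gives the highest number of the three, 17100 nM, and its gaps to compound 1 and to compound 2 both lie beyond the usual scatter. Compound 4 `COc1ccc(Cn2nc(-c3ccccc3)c3cc(C(=N)Nc4ccc(N5CCN(C)CC5)cc4)ncc32)cc1` has not yet been measured; it differs from compound 3 by 4-methoxybenzyl in place of hydrogen on an aromatic nitrogen. Because compound 1 gives 6300 nM and compound 2 gives 3540 nM, both carrying that same 4-methoxybenzyl group, a step of a 3.8-fold lower number from compound 3 to compound 4 (0.58 log units; beyond the scatter) is expected, a fall beyond the scatter. For compound 4 the estimate in this assay is 4500 nM, within 1800 nM to 11000 nM.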

Compound 4, half-maximal inhibitory concentration: 3990 nM
The estimate for compound 4 lay 1.1-fold (0.05 log units) above the measured number; low and high end bracket the measured number.
By their numbers in this assay, from the lowest: compounds 2, 4 and 1 (each within the scatter of the next); then compound 3.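

In this assay 4-methoxybenzyl in place of hydrogen on the aromatic nitrogen gives a 4.3-fold lower number from compound 3 to compound 4 (0.63 log units; beyond the scatter) and so shows, in a single change, that what sits on this nitrogen matters. The two other changes, hydrogen in place of cyclohexylamino with a 1.1-fold higher number from compound 2 to compound 4 (0.05 log units; within the scatter) and 4-methylpiperazin-1-yl in place of hydrogen with a 1.6-fold lower number from compound 1 to compound 4 (0.20 log units; within the scatter) as their steps, do not separate the compounds. No measurement shown explains the step on the nitrogen. As far as these compounds go, whether methyl or unsubstituted benzyl on that nitrogen would give a similar step remains open.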